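Dropping a Chloro Group: What to Expect for Compound 4

A few compounds are considered here, and "the series" means these few. Any claim that something is new, unique, unknown or untested is made for them only; others in the source may bear on it.

Compound 1 `CCOC(=O)[C@]1(C(=O)Nc2ccccc2)C[C@H]1c1cc(OC)c(OC)c(OC)c1` gives in a functional assay on HeLa cells (Homo sapiens) for cytotoxicity, read by MTT assay, with a stated time of 48 h (on this read-out lower numbers stand for stronger inhibition and higher numbers for weaker inhibition), the value > 100000 nM, which is a limit of the assay and not a number.
Compound 2 `CCOC(=O)[C@]1(C(=O)Nc2ccccc2Cl)C[C@H]1c1cc(OC)c(OC)c(OC)c1` gives in this assay 42400 nM.
Compound 3 `CCOC(=O)[C@@]1(C(=O)Nc2ccccc2Cl)C[C@H]1c1cc(OC)c(OC)c(OC)c1` gives in this assay 14400 nM.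

Compounds 2 and 3 share every atom and bond and differ only as the two compounds have the same atoms and bonds and differ only in configuration as drawn: 1 of 2 stereo elements differ; a stereocentre at a saturated ring carbon is drawn R in compound 2 and S in compound 3 sets out; this gives a 2.9-fold lower number from compound 2 to compound 3 (0.47 log units; beyond the scatter). Compound 4 `CCOC(=O)[C@@]1(C(=O)Nc2ccccc2)C[C@H]1c1cc(OC)c(OC)c(OC)c1` is not yet measured. It differs from compound 3 by hydrogen in place of chloro on an aromatic carbon, the same change that turns compound 2 into compound 1, (hydrogen in place of chloro on an aromatic carbon), where it gave an at least 2.3-fold higher number from compound 2 to compound 1 (0.37 log units; beyond the scatter), a step that rests on (the limit of > 100000 nM in this assay, at which 1 of the 3 values shown sits). Because the step of an at least 2.3-fold higher number from compound 2 to compound 1 (0.37 log units; beyond the scatter) points to weaker inhibition, compound 4 is expected to sit at 45000 nM, between 18000 nM and 150000 nM, meaning an estimated step of a 3.1-fold higher number from compound 3 to compound 4 (0.49 log units; beyond the scatter).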

Compound 4, half-maximal inhibitory concentration: > 100000 nM
Compound 4 was reported as a limit; the forecaster's own chance of this, stated with the estimate: 35%; middle value at least 2.2-fold (0.34 log units) away from the limit.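

Removing the chloro group gives a higher number, meaning weaker inhibition, on both cores in this assay, and on the core of compound 3 it gives an at least 6.9-fold higher number from compound 3 to compound 4 (0.84 log units; beyond the scatter). The direction therefore carries over from one core to the other, but both steps are only lower bounds, so their sizes cannot be compared: the same change on two cores in this assay, an at least 2.3-fold higher number (0.37 log units; beyond the scatter) from compound 2 to compound 1 and an at least 6.9-fold higher number (0.84 log units; beyond the scatter) from compound 3 to compound 4; the limit leaves it open whether they differ

Compounds 1 and 4 both sit at a limit of the assay, so the step between them cannot be read, and it stays unknown whether configuration still matters without the chloro group: the limit of > 100000 nM in this assay, at which 2 of the 4 values shown sit.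

As far as these compounds go, it also remains open how a bromo group, a methyl group or an amine in place of the chloro would compare on either core.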